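The compounds below may be only part of what the source reports. "The series", "measured", "known", "first", "only" and "open" are said of these compounds alone.

The two measured compounds are:
compound 1, `C=C(C)C(=O)N1CCC(CN(C2Cc3cc(C#N)ccc3N(Cc3cncn3C)C2)S(=O)(=O)c2ccccn2)CC1`, which in an ADME assay on Caco-2 cells (Homo sapiens) for permeability, in the apical to basolateral direction (a higher number here means that the compound crosses the layer faster, a lower number that the compound crosses the layer more slowly), gives 0.5 10^-6 cm/s;
compound 2, `CC(C)OC(=O)N1CCC(CN(C2Cc3cc(C#N)ccc3N(Cc3cncn3C)C2)S(=O)(=O)c2ccccn2)CC1`, which in this assay gives 1 10^-6 cm/s.

On these two numbers compound 2 holds the higher of the pair, but the gap to compound 1 is small: a 2.0-fold higher number from compound 1 to compound 2 (0.30 log units; within the scatter). For the measured compounds named here, that single step, an exchange on the same carbonyl carbon, is the only measured comparison available, and it did not rise above the scatter of the assay.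

Compound 3, `Cn1cncc1CN1CC(N(CC2CCN(C(=O)C3CC3)CC2)S(=O)(=O)c2ccccn2)Cc2cc(C#N)ccc21`, has not yet been measured. The difference from compound 2 is cyclopropyl in place of isopropoxy on a carbonyl carbon. Going by the values given here, the only step that bears on this change is a 2.0-fold higher number from compound 1 to compound 2 (0.30 log units; within the scatter), since it also alters the group on that carbonyl carbon, and it stayed within the scatter. On that basis no shift beyond the scatter is expected for compound 3, and the step is estimated as a 1.3-fold lower number from compound 2 to compound 3 (0.10 log units; within the scatter). Compound 3 is therefore expected to give about 0.8 10^-6 cm/s in this assay, with a likely range from 0.3 10^-6 cm/s to 2 10^-6 cm/s.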

Compound 3, apparent permeability: 0.5 10^-6 cm/s
For compound 3 the middle estimate is 1.6-fold (0.20 log units) above the measured one; the measured number falls inside the stated range.
By their numbers in this assay, from the lowest: compounds 1, 3 and 2 (each within the scatter of the next).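

In this assay the group on this carbonyl carbon now comes in three forms, and the exchange of isopropoxy for cyclopropyl, which replaces an open group holding an oxygen with a three-membered ring of carbon only, gives a 2.0-fold lower number from compound 2 to compound 3 (0.30 log units; within the scatter) and stays within the scatter. The exchange of 1-methylethenyl for cyclopropyl gives no change at the digits printed from compound 1 to compound 3 (within the scatter) so a ring on this carbon, a form the earlier pair did not include, cannot be told apart from either open group in this assay. No step at this position among these three compounds rises above the scatter, and nothing is available that would explain the readings.

What the compounds shown leave open is whether a group of another kind on this carbonyl carbon, such as an amine or a longer chain like n-butyl, would move the number beyond the scatter. As far as these compounds go, the nitrile and the rest of the shared core are the same in all three compounds, so what an exchange in those parts would do remains unknown.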